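A Benzyl Amine Replaces a Pyridyl Amine

A few compounds are considered here, and "the series" means these few. Any claim that something is new, unique, unknown or untested is made for them only; others in the source may bear on it.

Measured so far:
compound 1 `Cc1cc(Nc2nc(SCc3ccc(C(=O)Nc4ccccc4N)cc3)nn3cccc23)n[nH]1` — 959 nM
compound 2 `Cc1cccnc1Nc1nc(SCc2ccc(C(=O)Nc3ccccc3N)cc2)nn2cccc12` — 1370 nM

In a functional assay on HCT-116 cells (Homo sapiens) for antiproliferative activity, read by luminescence, with a stated time of 72 h, tested at 1 uM (a lower number here means a stronger inhibitor, a higher number a weaker inhibitor), compound 2 gives the higher of the two numbers; its nearest neighbour is compound 1, and the step of a 1.4-fold higher number from compound 1 to compound 2 (0.15 log units; within the scatter) lies within the scatter, so the two cannot be ranked. Compound 3 `COc1ccc(CNc2nc(SCc3ccc(C(=O)Nc4ccccc4N)cc3)nn3cccc23)cc1` is made from compound 2 by the change (4-methoxybenzyl in place of 3-methylpyridin-2-yl on a nitrogen on an aromatic ring). Within the data shown here, the only measured step, from compound 1 to compound 2, swaps one aromatic heterocycle for another and changes little. Among the measured compounds shown here, the new change is of a different kind: a benzyl group with a methylene link replaces a ring attached directly to the nitrogen, and no measured pair shows such a swap. The step of a 1.2-fold higher number from compound 2 to compound 3 (0.07 log units; within the scatter) is therefore expected to be modest, with no clear direction. Compound 3 is estimated at 1600 nM, within the range 550 nM to 5000 nM.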

Compound 3, half-maximal inhibitory concentration: 292 nM
For compound 3 the middle estimate is 5.5-fold (0.74 log units) above the measured one; the measured number lies below the stated range.
By their numbers in this assay, from the lowest: compound 3; then compounds 1 and 2 (each within the scatter of the next).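

In this assay, placing 4-methoxybenzyl on this nitrogen gives a 4.7-fold lower number from compound 2 to compound 3 (0.67 log units; beyond the scatter) and, set against the pyrazole-bearing compound, a 3.3-fold lower number from compound 1 to compound 3 (0.52 log units; beyond the scatter) as well. Among these compounds, the two rings attached directly to the nitrogen in compound 1 and compound 2 could not be ranked, so this is the first sign that the group at this place can move the number, here with a benzyl group joined through a methylene link. No measurement at hand explains the step.

The methylene link and the methoxy group enter together in compound 3, so the compounds shown cannot tell which of them, or whether the two together, accounts for the step. A plain benzyl group or a 4-methoxyphenyl ring on the same nitrogen would separate the two, and a longer chain such as 2-phenylethyl would test the length of the link.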